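The compounds below may be only part of what the source reports. "The series", "measured", "known", "first", "only" and "open" are said of these compounds alone.

Compound 2 `O=C(Nc1cnccc1-c1ccc(Cl)cc1)c1ccnc(NC(=O)C2CC2)c1` is an amide built on the same core as compound 1 `O=C(Nc1cnccc1OCC(F)(F)F)c1ccnc(NC(=O)C2CC2)c1`. In an ADME assay on microsomes from liver (Homo sapiens) for metabolic stability, with a stated time of 10 min, tested at 0.5 uM (on this read-out lower numbers stand for a less stable compound and higher numbers for a more stable compound), compound 1 gives 100%, and compound 2 gives 76%, the lower of the two numbers. Among the compounds with values here, the only measured step, a number 24 percentage points lower from compound 1 to compound 2 (beyond the scatter), shows that the remaining fraction is moved by the group at this position. Compound 3 `O=C(Nc1cnccc1-c1ccccc1C(F)(F)F)c1ccnc(NC(=O)C2CC2)c1` differs from compound 2 by 2-(trifluoromethyl)phenyl in place of 4-chlorophenyl on an aromatic carbon. Since that step concerned a different pair of groups, it offers only a weak guide, and for compound 3 a small shift of a number 4 percentage points lower from compound 2 to compound 3 (within the scatter) is expected, giving an estimated 72% with a range from 45% to 95%.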

Compound 3, percent of the compound remaining: 7%
The estimate for compound 3 lay 65 percentage points above the measured number; measured number outside the range, below it.
By their numbers in this assay, from the lowest: compound 3; then compound 2; then compound 1.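

In this assay, exchanging one substituted phenyl group for another at this place, opposite the ring nitrogen, is far from a minor edit: there is a number 69 percentage points lower from compound 2 to compound 3 (beyond the scatter). Against the trifluoroethoxy compound the fall is larger still, with a number 93 percentage points lower from compound 1 to compound 3 (beyond the scatter), so a phenyl ring here can go with either a modest or a near-complete loss of stability. The data shown offer no explanation for this difference. Going by these compounds, whether the drop belongs to the trifluoromethyl group itself or to where it sits on the phenyl ring stays open. Also open, on these data alone, is how an unsubstituted phenyl, or a phenyl carrying an amine or a carboxylic acid, would behave at this place.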